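This account rests on a few compounds, and the source may have more. Where it says the series, first, only, none or still open, it means among the compounds named here.

Measured so far:
- compound 1, `CCN(C(=O)c1c(O)c2c(F)cccc2n(C)c1=O)c1ccccc1`: 60%
- compound 2, `CCCN(C(=O)c1c(O)c2c(Cl)cccc2n(C)c1=O)c1ccccc1`: 94%
- compound 3, `C=CCN(C(=O)c1c(O)c2c(Cl)cccc2n(C)c1=O)c1ccccc1`: 59%

All three were tested in a functional assay on the whole organism for inhibition, with Mus musculus as the target, at a dose of 1 mg/kg by the oral route; a lower number here means less inhibition, a higher number more inhibition at the dose given (going by the name of the read-out). Compound 1 stands second highest of the three numbers; its nearest neighbour is compound 3, whose value lies within the scatter of it, while compound 2 stands well above it, beyond the scatter. Compound 2 and compound 1 differ in two places, so their values alone do not show which change carries the difference.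

Compound 4, `CCN(C(=O)c1c(O)c2c(C(F)(F)F)cccc2n(C)c1=O)c1ccccc1`, has not yet been measured. It differs from compound 1 in one place: trifluoromethyl in place of fluoro on an aromatic carbon.

For the measured compounds named here, the only step measured between two compounds that differ in a single place is a number 35 percentage points lower from compound 2 to compound 3 (beyond the scatter), which concerns the chain bound to the amide-type nitrogen, not the substituent on the aromatic ring. Going by the values given here, no measured step therefore bears directly on the change from compound 1 to compound 4. Compound 2, which carries a larger halogen on the ring than compound 1, gives the highest value, but that comparison is confounded by the chain change and cannot be read as a pattern.

With no direct guidance, the expectation for compound 4 is a step of a number 5 percentage points higher from compound 1 to compound 4 (within the scatter), lying within the scatter, so that compound 4 is estimated at 65% with a range from 35% to 90%.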

Compound 4, a percentage reported as inhibition, in the whole organism at one dose (the size of the read-out at that dose, not a potency): 80%
Beside the measured number, compound 4's estimate is 15 percentage points below it; measured number inside the range.
By their numbers in this assay, from the lowest: compounds 3 and 1 (each within the scatter of the next); then compound 4; then compound 2.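

In this assay, for the compounds shown here, trifluoromethyl in place of fluoro on an aromatic carbon gives a number 20 percentage points higher from compound 1 to compound 4 (beyond the scatter) while the chain on the amide-type nitrogen and the rest of the core stay the same, so this is the first single-change comparison at this ring position. It shows that the position is not indifferent to what it carries: exchanging one heavy atom for a group of four heavy atoms, neither group having a hydrogen-bond donor or acceptor, moves the inhibition seen at this single oral dose by more than the usual scatter. No measurement is available that explains the rise, so the step stands as an observation only.

Open, as far as these compounds go, is whether trifluoromethyl would have the same effect on the chain of compound 2, and where chloro at this position would fall on the chain shared by compound 1 and compound 4. Also open, from the compounds shown here alone, is how a plain hydrogen, a methyl, a methoxy or a nitrile on this aromatic carbon would compare with fluoro and trifluoromethyl.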